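The compounds below may be only part of what the source reports. "The series", "measured", "known", "first", "only" and "open" are said of these compounds alone.

Measured so far in a functional assay on A-431 cells (Homo sapiens) for antiproliferative activity, read by sulforhodamine B assay, with a stated time of 72 h; a lower number here means a stronger inhibitor, a higher number a weaker inhibitor:
Compound 1 `COCCNC(=O)Nc1cc2c(Nc3ccc(F)c(Cl)c3)ncnc2cc1O[C@H]1CCOC1` gives 387 nM.
Compound 2 `COC(CCNC(=O)Nc1cc2c(Nc3ccc(F)c(Cl)c3)ncnc2cc1O[C@H]1CCOC1)OC` gives 22000 nM.
Compound 3 `CN(C)CCN(C)C(=O)Nc1cc2c(Nc3ccc(F)c(Cl)c3)ncnc2cc1O[C@H]1CCOC1` gives 450 nM.

Compound 3 holds the second highest number of the three; its nearest neighbour is compound 1 (a 1.2-fold higher number from compound 1 to compound 3 (0.07 log units; within the scatter)), its furthest compound 2 (a 49-fold lower number from compound 2 to compound 3 (1.69 log units; beyond the scatter)). Compound 4 `O=C(Nc1cc2c(Nc3ccc(F)c(Cl)c3)ncnc2cc1O[C@H]1CCOC1)N1CC(O)C1` differs from compound 3 by 3-hydroxyazetidin-1-yl in place of (2-(dimethylamino)ethyl)(methyl)amino on a carbonyl carbon. Two measured steps change the group on the same carbonyl carbon: the swap from compound 1 to compound 3 stayed within the scatter, whereas the 3,3-dimethoxypropyl substituent in compound 2 cost heavily (a 57-fold higher number from compound 1 to compound 2 (1.75 log units; beyond the scatter)). Within the data shown here, a small cyclic substituent bearing one hydroxyl has no direct precedent here. The step from compound 3 to compound 4 in this assay is therefore expected to be modest, a 1.1-fold higher number from compound 3 to compound 4 (0.05 log units; within the scatter), with wide uncertainty. Compound 4 is estimated at 500 nM, in the range 150 nM to 2500 nM.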

Compound 4, half-maximal inhibitory concentration: 1930 nM
The estimate for compound 4 lay 3.9-fold (0.59 log units) below the measured number; low and high end bracket the measured number.
By their numbers in this assay, from the lowest: compounds 1 and 3 (each within the scatter of the next); then compound 4; then compound 2.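

At this carbonyl carbon, the 3-hydroxyazetidin-1-yl ring in compound 4 gives a weaker result in this assay than either open chain that showed no difference from each other (a 4.3-fold higher number from compound 3 to compound 4 (0.63 log units; beyond the scatter)) (a 5.0-fold higher number from compound 1 to compound 4 (0.70 log units; beyond the scatter)). It still stands well clear of the (3,3-dimethoxypropyl)amino group (an 11-fold lower number from compound 2 to compound 4 (1.06 log units; beyond the scatter)), so the position separates these three kinds of substituent. No supporting evidence accounts for this shift. The compounds shown do not separate the effect of the ring from that of its hydroxyl, and how an unsubstituted azetidine or a morpholine would read here remains open.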